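The source may hold more compounds than are shown below. What is called first, only, known or untested is meant among the compounds shown, and "the series" means these compounds.

Measured so far:
- compound 1, `CSc1nc2c([nH]1)C(=O)C=C(N(C)C)C2=O` — > 90 uM
- compound 2, `CSc1nc2c([nH]1)C(=O)C(Br)=C(Br)C2=O` — 40.3 uM

Going by the values given here, in a functional assay on MCF7 cells (Homo sapiens) for antiproliferative activity (on this read-out lower numbers stand for stronger inhibition and higher numbers for weaker inhibition), compound 2 gives 40.3 uM, the only numerical reading in the set. Among the compounds with values here, for compound 1 the value > 90 uM is a limit of the assay, not a number; this is the line (the limit of > 90 uM in this assay, at which 1 of the 2 values shown sits), so the set contains one number and one limit, and no step between measured compounds can be drawn.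

Compound 3, `CSc1nc2c([nH]1)C(=O)C=C(Br)C2=O`, is not yet measured. It differs from compound 2 by hydrogen in place of bromo on a double-bonded ring carbon — hydrogen in place of bromo on a double-bonded ring carbon. Within the data shown here, with no measured step to lean on, the expected change in this assay is small, on the weak side if anything, and possibly within the scatter. Compound 3 is accordingly expected near 60 uM, spanning 25 uM to 150 uM, a step from compound 2 of a 1.5-fold higher number from compound 2 to compound 3 (0.17 log units; within the scatter); the chance of only a limit being returned is real.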

Compound 3, concentration for 50% inhibition: 62.8 uM
For compound 3 the middle estimate is 1.0-fold (0.02 log units) below the measured one; the measured number falls inside the stated range.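

In this assay, hydrogen in place of bromo on a double-bonded ring carbon gives a 1.6-fold higher number from compound 2 to compound 3 (0.19 log units; within the scatter), so this bromo can be exchanged for hydrogen without a readable difference. Bromo in place of dimethylamino on a double-bonded ring carbon gives an at least 1.4-fold lower number from compound 1 to compound 3 (0.15 log units; that floor lies within the scatter), the first reading of that exchange, and only a floor can be stated for its size. Compound 1 gives a limit, not a number: the limit of > 90 uM in this assay, at which 1 of the 3 values shown sits.

The compounds shown leave open whether an amine such as methylamino, or a carboxylic acid, on this ring carbon would shift the reading beyond the scatter. Also open, on these data alone, is whether chloro or methoxy in place of the remaining bromo would give a reading that can be told apart from that of compound 3.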